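Trading Pyridine for Pyrazole on an Amide Nitrogen

A few compounds are considered here, and "the series" means these few. Any claim that something is new, unique, unknown or untested is made for them only; others in the source may bear on it.

Measured compounds:
compound 1 `Cc1ccc(OCC(=O)N(Cc2cccs2)c2ccccn2)cc1`: 200 nM
compound 2 `CCN(Cc1cccs1)C(=O)COc1ccc(Cl)cc1`: 39 nM

In an assay on HEK293 cells for agonist activity at transient receptor potential cation channel subfamily M member 8 (Homo sapiens), read by fluorescence and calcium flux, with a stated time of 15 min (a higher number here means that more compound is needed for the effect, a lower number that less compound is needed), compound 1 gives 200 nM. Of the two numbers measured, compound 1 stands highest; compound 2 gives 39 nM in this assay, and the gap between the two lies beyond the usual scatter. The unmeasured compound 3 `Cc1ccc(OCC(=O)N(Cc2cccs2)c2cnn(C)c2)cc1` differs from compound 1 in one place: 1-methyl-1H-pyrazol-4-yl in place of pyridin-2-yl on an amide-type nitrogen. Within the data shown here, no step between measured compounds matches this change, so nothing measured tells how large it should be. The account expects a modest step in this assay toward a higher number for compound 3, small enough that it could also fall within the scatter. The expected step is a 2.0-fold higher number from compound 1 to compound 3 (0.30 log units; within the scatter). Compound 3 is therefore estimated at 400 nM in this assay, with a range from 100 nM to 1500 nM.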

Compound 3, half-maximal effective concentration: 63000 nM
For compound 3 the middle estimate is 160-fold (2.20 log units) below the measured one; the whole stated range lies below it.
By their numbers in this assay, from the lowest: compound 2; then compound 1; then compound 3.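

Replacing pyridin-2-yl with 1-methyl-1H-pyrazol-4-yl on an amide-type nitrogen gives a 320-fold higher number from compound 1 to compound 3 (2.50 log units; beyond the scatter) in this assay, which shows that the value is highly sensitive to the group at this position. The two groups have the same count of heavy atoms and neither has a hydrogen-bond donor, so those counts alone do not set the value; they differ in ring size, hetero atoms and hydrogen-bond acceptors. No measurement here bears on why this exchange has so large an effect.

The compounds shown leave open whether the step belongs to the five-membered ring, its second nitrogen or its methyl group. Phenyl or the 1H-pyrazol-4-yl group without the methyl, placed on the same nitrogen, would begin to separate these features.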